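Salicylanilide replaces methoxybenzamide in a benzothiazole thioether series

A few compounds are considered here, and "the series" means these few. Any claim that something is new, unique, unknown or untested is made for them only; others in the source may bear on it.

Measured compounds:
compound 1 `COc1ccccc1C(=O)Nc1ccc(Sc2nc3ccccc3s2)cc1`: > 100000 nM
compound 2 `COc1ccccc1C(=O)Nc1ccccc1`: > 100000 nM
compound 3 `COc1ccccc1C(=O)Nc1ccc(Sc2nc3ccccc3s2)c(Cl)c1`: > 100000 nM

Compound 1 stands at a limit of an assay for inhibition of HSP60/HSP10 (Homo sapiens), with a stated time of 60 min; on this read-out lower numbers stand for stronger inhibition and higher numbers for weaker inhibition: its value of > 100000 nM is not a number but the edge of what the assay reports. Compound 2 likewise gives only the limit > 100000 nM in this assay. Compound 3 also sits at the limit, with > 100000 nM in this assay. All three compounds share this position, as the limit of > 100000 nM in this assay, at which 3 of the 3 values shown sit, records, and so a step that the two limits leave unreadable from compound 1 to compound 3 cannot be read.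

Compound 4 `O=C(Nc1ccc(Sc2nc3ccccc3s2)cc1)c1cc(Br)cc(Br)c1O` differs from compound 1 by 3,5-dibromo-2-hydroxyphenyl in place of 2-methoxyphenyl on a carbonyl carbon. For the measured compounds named here, none of the measured steps touches this part of the molecule, and none of them yields a readable size, so no measured step bears on the change. What can be said is that compound 1 leaves room only for a move toward stronger inhibition or none at all.

Compound 4 is therefore expected with considerable uncertainty: an estimate of 20000 nM, between 2000 nM and 100000 nM, which would be a step of an at least 5.0-fold lower number from compound 1 to compound 4 (0.69 log units; beyond the scatter) toward stronger inhibition, though a further limit remains possible.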

Compound 4, half-maximal inhibitory concentration: 4700 nM
Compound 4: middle estimate off by 4.3-fold (0.63 log units), on the high side; the range from low to high includes it.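

In this assay, for the compounds shown here, putting 3,5-dibromo-2-hydroxyphenyl in place of 2-methoxyphenyl on a carbonyl carbon gives an at least 21-fold lower number from compound 1 to compound 4 (1.32 log units; beyond the scatter), which is the first readable step. The earlier compounds shown here could not show whether any change moved the read-out, and the step involving the chloro group cannot be read, whereas compound 4 shows that this part of the molecule can carry a large move toward stronger inhibition. The size of the step remains a bound, because compound 1 gives only a limit: the limit of > 100000 nM in this assay, at which 3 of the 4 values shown sit.

The change swaps methoxy for hydroxy and adds two bromines at once, so the compounds shown do not separate the contribution of each. As far as these compounds go, how a plain phenyl, or a carboxylic acid or an amine on that ring, would read remains open.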